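Hexafluoroisopropyl ester series at the adenosine A3 receptor

The compounds below may be only part of what the source reports. "The series", "measured", "known", "first", "only" and "open" are said of these compounds alone.

Working notes on a small dihydropyrimidinone ester set. Compound 1 `CC1=C(C(=O)OC(C)C(F)(F)F)C(c2ccco2)NC(=O)N1` has two entries in an assay on HeLa cells for displacement of a labelled ligand from adenosine receptor A3 (Homo sapiens), read by radioligand binding, with a stated time of 180 min, tested at 1 uM (on this read-out lower numbers stand for less inhibition and higher numbers for more inhibition at the one concentration tested (going by the name of the read-out)), giving 11%; 7% (2 entries); both entries lie within the usual scatter of each other (the several entries of compound 1 in this assay, 11%; 7% (2 entries)). Compound 2 `CC1=C(C(=O)OC(C(F)(F)F)C(F)(F)F)C(c2cccs2)NC(=O)N1` carries the hexafluoroisopropyl ester and the thiophen-2-yl group; in this assay compound 2 gives 1%, the only number shown for it, and a further entry without a single number. Compound 3 `CC1=C(C(=O)OC(C(F)(F)F)C(F)(F)F)C(c2ccco2)NC(=O)N1` keeps the ester of compound 2 and differs from it by the change (furan-2-yl in place of thiophen-2-yl on a saturated ring carbon). Going by the values given here, no measured pair differs only in this place, so no measured step is known for it. The expected step in this assay from compound 2 to compound 3 is a number 4 percentage points higher from compound 2 to compound 3 (within the scatter), a shift upward that stays within the scatter. For compound 3 the estimated value in this assay is 5%, in the range -5% to 15%.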

Compound 3, a percentage reported as inhibition, at one concentration (the size of the read-out at that concentration, not a potency): 2%
The estimate for compound 3 lay 3 percentage points above the measured number; low and high end bracket the measured number.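

Going by these compounds alone, the pair gives the first measured step at this place, on a saturated ring carbon of a six-membered non-aromatic ring with 2 nitrogen, with the hexafluoroisopropyl ester held fixed: in this assay the exchange gives a number 1 percentage points higher from compound 2 to compound 3 (within the scatter) and so does not separate furan-2-yl from thiophen-2-yl. With both compounds giving so little inhibition at the one concentration tested, the step says nothing about how this position would respond in a compound with more inhibition. The repeated entries show how far two readings can lie apart without meaning anything: the several entries of compound 1 in this assay, 11%; 7% (2 entries).

The compounds shown leave open whether a phenyl group at this place would separate from the two five-membered aromatic rings. They also leave open whether an amine on that ring or a longer chain in the ester would move the read-out beyond the scatter.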